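A Chain Rearrangement on a Shared Core

The compounds below may be only part of what the source reports. "The series", "measured", "known", "first", "only" and "open" are said of these compounds alone.

Compound 1 `CC(C)NCCOc1c(O)cc(O)c2c(=O)cc(-c3ccccc3)oc12` has no result in a functional assay on A549 cells (Homo sapiens) for cytotoxicity, read by MTT assay, with a stated time of 48 h (a lower number here means a stronger inhibitor, a higher number a weaker inhibitor), its entry there reading "not determined" (no result reported). Within the data shown here, compound 2 `COc1c(O)cc(O)c2c(=O)cc(-c3ccc(Cl)cc3)oc12` is likewise without a number in this assay, its entry reading "not determined" (no result reported), so no step from compound 1 can be sized. Among the measured compounds shown here, the one anchor is compound 3 `CCN(CC)CCCCOc1cc(O)c2c(=O)cc(-c3ccccc3)oc2c1OC`, which in this assay gives 1000 nM. Compound 4 `CN(C)CCCOc1c(O)cc(O)c2c(=O)cc(-c3ccccc3)oc12` differs from compound 1 by (dimethylamino)methyl in place of isopropylamino on a saturated chain carbon, two bonds along the chain from an oxygen on an aromatic ring. With no number for compound 1, no direction or size of change in this assay can be stated for this step; the expectation rests only on compound 3. Compound 4 is therefore expected to give about 1500 nM in this assay, within a range of 300 nM to 8000 nM, resting on the value of compound 3, which was 1000 nM.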

Compound 4, half-maximal inhibitory concentration: > 100000 nM
Compound 4 gave a limit, no number (the forecaster's own chance of this, stated with the estimate: 20%); middle value at least 66-fold (1.82 log units) from the limit.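

In this assay, among these compounds, compound 4 gives > 100000 nM, a limit and not a number, and compound 1 has no result, so no step between compound 1 and compound 4 can be read. The compounds shown leave open what the change from isopropylamino to (dimethylamino)methyl does in this assay.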